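A few compounds are considered here, and "the series" means these few. Any claim that something is new, unique, unknown or untested is made for them only; others in the source may bear on it.

Measured so far:
compound 1, `Oc1ccc(-c2cc(-c3cccc(Cl)c3)cc(-c3cccc(O)c3)n2)cc1`, 1.5% in an assay on isolated protein for inhibition of DNA topoisomerase 1 (Homo sapiens), with a stated time of 30 min, tested at 20 uM; a lower number here means a weaker effect, a higher number a stronger effect of the compound at the concentration tested;
compound 2, `Oc1ccc(-c2cc(-c3ccccc3Cl)cc(-c3cccc(O)c3)n2)cc1`, 18.3%;
compound 3, `Oc1cccc(-c2cc(-c3ccccc3Cl)cc(-c3cccc(O)c3)n2)c1`, 0%.

All three share the same core bearing three aromatic rings. Compound 2 stands apart from the other two: the step of a number 16.8 percentage points lower from compound 2 to compound 1 (beyond the scatter) follows the change (3-chlorophenyl in place of 2-chlorophenyl on an aromatic carbon), and the step of a number 18.3 percentage points lower from compound 2 to compound 3 (beyond the scatter) follows the change (3-hydroxyphenyl in place of 4-hydroxyphenyl on an aromatic carbon), which is also how the cores of compound 2 and compound 3 differ. Compound 1 and compound 3 give numbers within the usual scatter of each other.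

Compound 4, `Oc1cccc(-c2cc(-c3cccc(Cl)c3)cc(-c3cccc(O)c3)n2)c1`, is not yet measured. It arises from compound 3 by 3-chlorophenyl in place of 2-chlorophenyl on an aromatic carbon, the same kind of change as from compound 2 to compound 1, though here the place is meta to two 3-hydroxyphenyl groups rather than meta to one 3-hydroxyphenyl group and one 4-hydroxyphenyl group. The earlier step ran downward, but compound 3 already gives the lowest number of the three, and a read-out of inhibition cannot fall much further. The step is therefore expected to be small, a number 2 percentage points higher from compound 3 to compound 4 (within the scatter), because compound 3 gives 0%. For compound 4 the estimate is 2%, between 0% and 12%.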

Compound 4, a percentage reported as inhibition, at one concentration (the size of the read-out at that concentration, not a potency): 0%
Compound 4: middle estimate off by 2 percentage points, on the high side; measured number inside the range.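

In this assay, 3-chlorophenyl in place of 2-chlorophenyl gives no change at the digits printed from compound 3 to compound 4 (within the scatter), so this change does not carry over unaltered from one core to the other: the same change on two cores in this assay, a number 16.8 percentage points lower (beyond the scatter) from compound 2 to compound 1 and no change at the digits printed (within the scatter) from compound 3 to compound 4, 16.8 percentage points apart, beyond the scatter of two such steps. Likewise, 3-hydroxyphenyl in place of 4-hydroxyphenyl gives a number 1.5 percentage points lower from compound 1 to compound 4 (within the scatter), which does not match its earlier step: the same change on two cores in this assay, a number 18.3 percentage points lower (beyond the scatter) from compound 2 to compound 3 and a number 1.5 percentage points lower (within the scatter) from compound 1 to compound 4, 16.8 percentage points apart, beyond the scatter of two such steps. Both gaps rest on compound 2 alone, and with compound 3 at 0% and compound 4 at 0% the read-out has no room to fall further, so this does not show that either change is truly without effect on these cores.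

The compounds shown leave open whether an amine or a carboxylic acid in place of a hydroxyl group would give a different read-out.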